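The source may hold more compounds than are shown below. What is called first, only, known or untested is meant among the compounds shown, and "the series" means these compounds.

Measured compounds in the series:

compound 1 `COc1nn(Cc2ccc(N)cc2)c(=O)o1` — 34%
compound 2 `COc1nn(Cc2ccc(NC(C)=O)cc2)c(=O)o1` — 37%

In an assay on COS-7 cells for inhibition of Fatty-acid amide hydrolase 1 (Homo sapiens), read by scintillation counting, with a stated time of 10 min, tested at 10 uM (a higher number here means more inhibition at the concentration tested (going by the name of the read-out), a lower number less inhibition), compound 1 gives 34% and compound 2 gives 37%. Of the two numbers, compound 2 has the higher one, but the step of a number 3 percentage points higher from compound 1 to compound 2 (within the scatter) is within the scatter, so the two compounds cannot be ordered on this assay.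

Compound 3 `COc1nn(Cc2ccc(C#N)cc2)c(=O)o1` is the next member. The change from compound 2: cyano in place of acetamido on an aromatic carbon

Going by the values given here, no measured step bears directly on a cyano group; the only step known, a number 3 percentage points higher from compound 1 to compound 2 (within the scatter), swaps hydrogen for acetyl on the same nitrogen and is within the scatter. Both measured compounds sit in a narrow band, and there is nothing to show that removing the acetamido group moves the number outside it. The expectation for compound 3 in this assay is therefore a step of about a number 4 percentage points lower from compound 2 to compound 3 (within the scatter), that is, none beyond the scatter.

Compound 3 is estimated at 33%, with a range from 15% to 52%.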

Compound 3, a percentage reported as inhibition, at one concentration (the size of the read-out at that concentration, not a potency): "not active" (no number reported)
Compound 3 has no reported number here; there is nothing to compare the estimate with.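

In this assay, going by these compounds alone, compound 3 is reported as "not active" with no number, so no step from compound 2 to compound 3 can be read. The compounds shown leave open what cyano in place of acetamido does to inhibition. Nothing at hand explains this result.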